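The source may hold more compounds than are shown below. What is called first, only, known or untested is meant among the compounds shown, and "the series" means these compounds.

Measured compounds: compound 1 `NC(CCSCCNCC(=O)O)C(=O)O` with 37.1%; compound 2 `CC(C)(CCSCCC(N)C(=O)O)CC(=O)O` with 100%; compound 3 `CC(CCSCCC(N)C(=O)O)CC(=O)O` with 100%.

In an assay for inhibition of betaine--homocysteine S-methyltransferase 1 (Homo sapiens), tested at 20 uM (a lower number here means less inhibition, a higher number more inhibition at the concentration tested (going by the name of the read-out)), compound 1 gives 37.1%, the lowest of the three numbers, while compound 2 gives 100% and compound 3 gives 100%, each beyond the scatter above compound 1. Compound 4 `C[C@@H](NCCSCCC(N)C(=O)O)C(=O)O` differs from compound 1 by methyl in place of hydrogen on a saturated chain carbon bound to an amine nitrogen and a carbonyl carbon. For the measured compounds named here, the only measured step, no change at the digits printed from compound 2 to compound 3 (within the scatter), concerns a methyl at a different place, on a saturated chain carbon bound to three saturated chain carbons, and therefore bears only loosely on this change. With nothing closer to go on, the step of a number 2.9 percentage points higher from compound 1 to compound 4 (within the scatter) expected in this assay is none beyond the scatter. Compound 4 is accordingly estimated at 40%, within 15% to 70%.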

Compound 4, a percentage reported as inhibition, at one concentration (the size of the read-out at that concentration, not a potency): 15.5%
Estimate against measurement, compound 4: 24.5 percentage points above; low and high end bracket the measured number.
By their numbers in this assay, from the lowest: compound 4; then compound 1; then compounds 2 and 3 (each within the scatter of the next).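

In this assay, for the compounds shown here, this is the first reading at this position, and methyl in place of hydrogen on a saturated chain carbon bound to an amine nitrogen and a carbonyl carbon is not silent here: the change, carboxymethyl to 1-carboxyethyl, gives a number 21.6 percentage points lower from compound 1 to compound 4 (beyond the scatter). The same exchange of hydrogen and methyl therefore does not read alike at the two places: the same change on two cores in this assay, no change at the digits printed (within the scatter) from compound 2 to compound 3 and a number 21.6 percentage points higher (beyond the scatter) from compound 4 to compound 1, 21.6 percentage points apart, beyond the scatter of two such steps

Going by these compounds, what an ethyl group or a longer chain would do on this carbon stays open. So does the effect of an amide in place of the carboxylic acid of the 1-carboxyethyl group.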